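Chain-end variation on the allyl acetophenone ether series

The compounds below may be only part of what the source reports. "The series", "measured", "known", "first", "only" and "open" are said of these compounds alone.

Measured so far:
compound 1, `C#CCCCCOc1cc(O)c(C(C)=O)cc1CC=C`: in an assay on isolated protein for binding affinity to leukotriene B4 receptor 1 (Homo sapiens), tested at 1 uM (on this read-out lower numbers stand for less inhibition and higher numbers for more inhibition at the one concentration tested (going by the name of the read-out)), compound 1 gives 29%
compound 2, `C=CCc1cc(C(C)=O)c(O)cc1OCCCCCC(C)(C)O`: in this assay compound 2 gives 60%

Within the data shown here, compound 2 stands highest of the two numbers measured; the only neighbour is compound 1, and the step between them is a number 31 percentage points higher from compound 1 to compound 2 (beyond the scatter). The shared core is untouched in both, so the whole difference rests on the end of the chain.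

The next compound, compound 3, `C=CCc1cc(C(C)=O)c(O)cc1OCCCCCC(=O)OC`, differs from compound 2 as follows: methoxycarbonyl in place of 1-hydroxy-1-methylethyl on a saturated chain carbon, five bonds along the chain from an oxygen on an aromatic ring. The change therefore removes the only hydrogen-bond donor on the chain end and replaces it with an ester carrying two acceptors.

Among the measured compounds shown here, the one step that bears on this is a number 31 percentage points higher from compound 1 to compound 2 (beyond the scatter), which shows that the chain end alone can move the read-out by a large amount. For the measured compounds named here, no measured pair shows what removing the donor while keeping the chain length does, so the direction is uncertain. On balance a moderate fall in this assay is expected, a number 15 percentage points lower from compound 2 to compound 3 (beyond the scatter), with a wide range. Compound 3 is estimated at 45%, between 20% and 70%.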

Compound 3, a percentage reported as inhibition, at one concentration (the size of the read-out at that concentration, not a potency): 65%
The estimate for compound 3 lay 20 percentage points below the measured number, and the stated range covers the measured number.
By their numbers in this assay, from the lowest: compound 1; then compounds 2 and 3 (each within the scatter of the next).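

In this assay, methoxycarbonyl in place of 1-hydroxy-1-methylethyl on a saturated chain carbon, five bonds along the chain from an oxygen on an aromatic ring, gives a number 5 percentage points higher from compound 2 to compound 3 (within the scatter) and so leaves the read-out within the scatter, even though the entering group has 0 hydrogen-bond donors; a donor on the chain end is therefore not required to keep the read-out at the level of compound 2. Set against the ethynyl end, the ester end gives a number 36 percentage points higher from compound 1 to compound 3 (beyond the scatter), so the large step first seen with 2-hydroxy-2-methylpropyl also appears with (methoxycarbonyl)methyl and is not tied to the hydroxyl group. No measurement available here accounts for why these two different chain ends read alike.

As far as these compounds go, whether a carboxylic acid, a primary amide or an amine on the chain end would give a read-out in the same range stays open, as does the outcome of a shorter or longer chain carrying the methoxycarbonyl group. From the compounds shown here alone, with readings at one concentration only, it also stays open whether compound 2 and compound 3 would match in potency.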